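Chloro in Place of Hydrogen: From Compound 3 to Compound 4

The compounds below may be only part of what the source reports. "The series", "measured", "known", "first", "only" and "open" are said of these compounds alone.

Of the compounds shown here, three sharing one core have been measured. Compound 1 `COc1cc(OC)c(C(=O)/C=C/c2ccccc2SC)c(OC)c1` gives 25% in a functional assay on HCT-116 cells (Homo sapiens), read by fluorescence and BrdU incorporation, with a stated time of 48 h, tested at 10 uM; a lower number here means a stronger effect, a higher number a weaker effect of the compound at the concentration tested. Compound 2 `COc1cccc(/C=C/C(=O)c2c(OC)cc(OC)cc2OC)c1` gives 20% in this assay, and compound 3 `COc1cc(OC)c(C(=O)/C=C/c2ccccc2)c(OC)c1` gives 19%. Compound 3 stands with the lowest of the three numbers, but its nearest neighbour is compound 2 and its furthest is compound 1, and both gaps lie within the scatter, so the three cannot be told apart. The single-change steps agree: a number 5 percentage points lower from compound 1 to compound 2 (within the scatter), a number 6 percentage points lower from compound 1 to compound 3 (within the scatter) and a number 1 percentage points lower from compound 2 to compound 3 (within the scatter).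

Compound 4 `COc1cc(OC)c(C(=O)/C=C/c2ccc(Cl)cc2)c(OC)c1` differs from compound 3 by chloro in place of hydrogen on an aromatic carbon. Going by the values given here, no measured step puts chloro onto that ring; the steps that changed a group on the same ring, a number 6 percentage points lower from compound 1 to compound 3 (within the scatter) and a number 1 percentage points lower from compound 2 to compound 3 (within the scatter), stayed within the scatter, as did a number 5 percentage points lower from compound 1 to compound 2 (within the scatter). On that basis the account expects no step beyond the scatter for compound 4, that is a number 1 percentage points higher from compound 3 to compound 4 (within the scatter). For compound 4 the estimated value in this assay is 20%, with an expected range from 8% to 35%.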

Compound 4, a percentage reported as activity, at one concentration (the size of the read-out at that concentration, not a potency): 18%
For compound 4 the middle estimate is 2 percentage points above the measured one, and the stated range covers the measured number.
By their numbers in this assay, from the lowest: compounds 4, 3, 2 and 1 (each within the scatter of the next).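

In this assay the step of a number 1 percentage points lower from compound 3 to compound 4 (within the scatter) is the only one shown that places a group para to a large group, and with chloro there the read-out stays within the scatter of the plain phenyl compound. The exchanges of the whole aryl group read the same way, with a number 2 percentage points lower from compound 2 to compound 4 (within the scatter) for 4-chlorophenyl in place of 3-methoxyphenyl and a number 7 percentage points lower from compound 1 to compound 4 (within the scatter) for 4-chlorophenyl in place of 2-(methylsulfanyl)phenyl, so among these four compounds chloro, methoxy and methylsulfanyl on this ring give no step beyond the scatter. No evidence is available that accounts for this flat picture.

On these data alone, what stays open is whether a group of another kind at this place, such as an amine, a carboxylic acid or a longer chain, would give a step beyond the scatter. Also open, as far as these compounds go, is how the read-out would answer to a change in the shared core, which all four compounds carry unaltered, and how they would compare at concentrations other than the single one tested.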